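A ring swap on the spin-labelled amide

The source may report more compounds than this note shows. Statements on the series, on what has been measured and on what is new or still open speak of the compounds shown alone.

Values in a functional assay on BGC832 cells (Homo sapiens) for cytotoxicity, read by MTT assay, with a stated time of 24 h; a higher number here means a weaker inhibitor, a lower number a stronger inhibitor:
- Compound 1 `COc1ccc(/C=C\c2cc(OC)c(OC)c(OC)c2)cc1NC(=O)C1=CC(C)(C)N([O])C1(C)C`: > 100000 nM
- Compound 2 `COc1ccc(/C=C\c2cc(OC)c(OC)c(OC)c2)cc1NC(=O)C1CC(C)(C)N([O])C1(C)C`: 4930 nM

Within the data shown here, compound 2 holds the only exact number so far. For compound 1 there is only a limit, (the limit of > 100000 nM in this assay, at which 1 of the 2 values shown sits). Among the measured compounds shown here, the one measured step, an at least 20-fold lower number from compound 1 to compound 2 (1.30 log units; beyond the scatter), is large and beyond the scatter.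

Compound 3 `COc1ccc(/C=C\c2cc(OC)c(OC)c(OC)c2)cc1NC(=O)C1=CC(C)(C)N([O])C(C)(C)C1` keeps the shared core and the amide and changes the group on the carbonyl carbon: a group of 11 heavy atoms (9 carbon, 1 nitrogen, 1 oxygen; one six-membered non-aromatic ring with 1 hetero atom) in place of a group of 10 heavy atoms (8 carbon, 1 nitrogen, 1 oxygen; one five-membered non-aromatic ring with 1 hetero atom), on a carbonyl carbon. The new group holds a double bond outside aromatic rings. The group in compound 1 holds one too, while that of compound 2 does not. For the measured compounds named here, no measured step changes the ring size, so the step to compound 2 is an indirect guide, and it rests on two compounds only. With an at least 20-fold lower number from compound 1 to compound 2 (1.30 log units; beyond the scatter) as that guide, a moderate move to a higher, weaker number is expected in this assay, though with wide uncertainty. For compound 3 the estimated value is 15000 nM, with an expected range of 2500 nM to 100000 nM. The expected change is a 3.0-fold higher number from compound 2 to compound 3 (0.48 log units; beyond the scatter).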

Compound 3, half-maximal inhibitory concentration: 6210 nM
The estimate for compound 3 lay 2.4-fold (0.38 log units) above the measured number, within the range that was stated.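

In this assay, the six-membered ring with a double bond outside aromatic rings and the five-membered ring without one cannot be told apart on the carbonyl carbon: a 1.3-fold higher number from compound 2 to compound 3 (0.10 log units; within the scatter). A double bond in the group therefore does not by itself go with the weak reading of compound 1, as compound 3 carries one as well, and the change of ring size alone gives an at least 16-fold lower number from compound 1 to compound 3 (1.20 log units; beyond the scatter). The value of compound 1 is a limit of the assay and not a number, so this step has no exact size: the limit of > 100000 nM in this assay, at which 1 of the 3 values shown sits.

Still open, as far as these compounds go, is how a six-membered ring without the double bond would read, as compound 2 and compound 3 differ in both ring size and double bond, so the two features cannot be separated here. Also open, from the compounds shown here alone, is whether the ring nitrogen and its oxygen matter at all, which an all-carbon cyclohexyl group on the same carbonyl carbon would show.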